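The source may hold more compounds than are shown below. What is called first, only, known or untested is meant among the compounds shown, and "the series" means these compounds.

In a functional assay on T47D cells (Homo sapiens) for inhibition, read by MTT assay, with a stated time of 48 h (on this read-out lower numbers stand for stronger inhibition and higher numbers for weaker inhibition), compound 1 (`CCOC(=O)c1c(N)sc(/N=C/c2ccc([N+](=O)[O-])o2)c1C(=O)OCC`) gives 16000 nM, within the scatter of both other measured compounds: compound 2 (`CCOC(=O)c1c(N)sc(/N=C/c2ccncc2)c1C(=O)OCC`) gives 8600 nM and compound 3 (`CCOC(=O)c1c(N)sc(/N=C/c2ccccc2)c1C(=O)OCC`) gives 30300 nM. Compound 4 (`CCOC(=O)c1c(N)sc(/N=C/c2ccco2)c1C(=O)OCC`) carries hydrogen in place of nitro on an aromatic carbon. Among the compounds with values here, no measured step isolates this change. Within the data shown here, exchanging the whole 5-nitrofuran-2-yl group gave only a 1.9-fold lower number from compound 1 to compound 2 (0.27 log units; within the scatter) and a 1.9-fold higher number from compound 1 to compound 3 (0.28 log units; within the scatter), while the one step beyond the scatter is a 3.5-fold higher number from compound 2 to compound 3 (0.55 log units; beyond the scatter). Compound 1 at 16000 nM therefore serves as the anchor, and no step beyond the scatter is expected in this assay. The expected change is a 1.1-fold higher number from compound 1 to compound 4 (0.03 log units; within the scatter). For compound 4 the estimated value is 17000 nM, with an expected range of 7000 nM to 40000 nM.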

Compound 4, half-maximal inhibitory concentration: 14900 nM
Compound 4: middle estimate off by 1.1-fold (0.06 log units), on the high side, within the range that was stated.
By their numbers in this assay, from the lowest: compounds 2, 4, 1 and 3 (each within the scatter of the next, the first and the last beyond it).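

Taken alone, the nitro group, next to the ring oxygen, shows no effect beyond the scatter in this assay: the step is a 1.1-fold lower number from compound 1 to compound 4 (0.03 log units; within the scatter) and hydrogen cannot be told apart from nitro at this position. The furan-2-yl group separates from phenyl, with a 2.0-fold lower number from compound 3 to compound 4 (0.31 log units; beyond the scatter), but not from pyridin-4-yl, with a 1.7-fold higher number from compound 2 to compound 4 (0.24 log units; within the scatter). No available evidence bears on these steps. Open remains whether an amine or a carboxylic acid on this same aromatic carbon would give a step beyond the scatter from compound 4.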